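This account rests on a few compounds, and the source may have more. Where it says the series, first, only, none or still open, it means among the compounds named here.

In a functional assay on MCF7 cells (Homo sapiens) for cytotoxicity, read by sulforhodamine B assay (on this read-out higher numbers stand for weaker inhibition and lower numbers for stronger inhibition), compound 1 `C=C1[C@@H](OC(C)=O)C[C@@H]2[C@](C)(CO[Si](C)(C)C(C)(C)C)[C@H](OC(C)=O)CC[C@@]2(C)[C@@H]1C[C@@H](Nc1ccc(OC)c(OC)c1)C1=CCOC1=O` gives 4310 nM, the lowest of the numbers shown, and compound 2 `C=C1[C@@H](OC(C)=O)C[C@@H]2[C@](C)(COC=O)[C@H](OC(C)=O)CC[C@@]2(C)[C@@H]1C[C@@H](Nc1cccc(F)c1)C1=CCOC1=O` gives 14100 nM. Compound 3 `C=C1[C@@H](OC(C)=O)C[C@@H]2[C@](C)(COC=O)[C@H](OC(C)=O)CC[C@@]2(C)[C@@H]1C[C@@H](Nc1ccc(OC)c(OC)c1)C1=CCOC1=O` stands at > 50000 nM, which is a limit of the assay and not a number.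

Compound 4 `C=C1[C@@H](OC(C)=O)C[C@@H]2[C@](C)(CO[Si](C)(C)C(C)(C)C)[C@H](OC(C)=O)CC[C@@]2(C)[C@@H]1C[C@@H](Nc1ccc(C(=O)O)cc1)C1=CCOC1=O` differs from compound 1 on an amine nitrogen, with 4-carboxyphenyl in place of 3,4-dimethoxyphenyl on an amine nitrogen. The rest of compound 1 stays as it is.

One measured change bears directly on that nitrogen. With 3,4-dimethoxyphenyl in place of 3-fluorophenyl, it gave an at least 3.5-fold higher number from compound 2 to compound 3 (0.54 log units; beyond the scatter), so the group there can move the number beyond the scatter in this assay. However, 4-carboxyphenyl appears in no measured compound. The other step, an at least 11-fold higher number from compound 1 to compound 3 (1.06 log units; beyond the scatter), is large but lies elsewhere in the molecule, at a place that compound 4 shares with compound 1.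

Compound 1 at 4310 nM starts from the lowest number shown, so a modest rise is expected rather than a fall, with wide uncertainty. The expected change is a 1.9-fold higher number from compound 1 to compound 4 (0.27 log units; within the scatter). For compound 4 the estimated value is 8000 nM, with an expected range from 2000 nM to 35000 nM.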

Compound 4, half-maximal inhibitory concentration: 3990 nM
Compound 4: the middle estimate sits 2.0-fold (0.30 log units) above what was measured; the range from low to high includes it.
By their numbers in this assay, from the lowest: compounds 4 and 1 (each within the scatter of the next); then compound 2. At a limit, above all of these: compound 3.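

In this assay, among the compounds shown here, the first comparison at the amine nitrogen made with the larger silyl group kept on the oxygen gives a 1.1-fold lower number from compound 1 to compound 4 (0.03 log units; within the scatter). The number therefore does not separate 3,4-dimethoxyphenyl from 4-carboxyphenyl on the core of compound 1, even though the entering group carries a hydrogen-bond donor and the leaving group carries none. For the compounds shown here, the only earlier step at this nitrogen, an at least 3.5-fold higher number from compound 2 to compound 3 (0.54 log units; beyond the scatter), involved a different pair of aryl groups and the smaller group on the oxygen, so the nitrogen's substituent can move the number in one setting and leave it within the scatter in another.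

The compounds shown leave open whether a methyl ester or an amide in place of the carboxylic acid, or a plain phenyl on the nitrogen, would hold the number at this level, and whether 4-carboxyphenyl would do the same with the smaller group on the oxygen. Compound 3 offers only a limit and not a number for any such comparison: the limit of > 50000 nM in this assay, at which 1 of the 4 values shown sits.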